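The compounds below may be only part of what the source reports. "The series", "measured", "known", "first", "only" and "open" are said of these compounds alone.

Compound 1 `NC(=O)N[C@H]1[C@@H](O)[C@H](n2cnc3c(NCc4cccc(I)c4)nc(Cl)nc32)O[C@@H]1CO` and compound 2 `CNC(=O)[C@H]1O[C@@H](n2cnc3c(NCc4cccc(I)c4)ncnc32)[C@H](O)[C@@H]1NC(N)=O` share a core built around a five-membered ring with one oxygen, carrying a substituted purine and a chain that ends in an iodinated benzyl group. In an in vitro assay on COS-7 cells for displacement of a labelled ligand from adenosine receptor A3 variant H272E (Homo sapiens) (a lower number here means a stronger inhibitor, a higher number a weaker inhibitor), compound 1 gives 200 nM, while compound 2 gives 2700 nM. Compound 2 therefore stands at the high end of the two numbers, and its gap to compound 1 lies well beyond the scatter of repeated measurements. Compound 3 `CNC(=O)[C@H]1O[C@@H](n2cnc3c(NCc4cccc(I)c4)ncnc32)[C@H](O)[C@@H]1N=[N+]=[N-]` is the next compound in this series and has not yet been measured. It differs from compound 2 in one place: azido in place of ureido on a saturated ring carbon, that is, an azido in place of a ureido on a saturated ring carbon. Among the measured compounds shown here, no measured pair shows this particular exchange, so the size of the step can only be guessed. The expected step of a 1.8-fold lower number from compound 2 to compound 3 (0.26 log units; within the scatter) is a modest move toward a lower number, though it may stay within the scatter. Compound 3 is estimated at 1500 nM, with a range from 300 nM to 8000 nM.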

Compound 3, inhibition constant: 186 nM
The estimate for compound 3 lay 8.1-fold (0.91 log units) above the measured number, and the stated range ends above it.
By their numbers in this assay, from the lowest: compounds 3 and 1 (each within the scatter of the next); then compound 2.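

In this assay, the saturated ring carbon that bears the ureido group in compound 2 proves sensitive to what sits on it: azido in place of ureido gives a 15-fold lower number from compound 2 to compound 3 (1.16 log units; beyond the scatter). This single exchange moves the number far beyond the scatter, so the group at this position matters in this series. The ureido group counts 2 hydrogen-bond donors and the azido group 0 hydrogen-bond donors, but one pair cannot show whether that difference matters, and nothing measured here explains the size of the step.

From the compounds shown here alone, it remains open whether an amine, an acetamido group or a hydroxy group on the same carbon would give a number closer to that of compound 3 or to that of compound 2. Going by these compounds, it also remains open whether the same exchange would have a similar effect on the core of compound 1.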